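A few compounds are considered here, and "the series" means these few. Any claim that something is new, unique, unknown or untested is made for them only; others in the source may bear on it.

Compound 1 `C/C=C1/[C@H](O[C@@H]2O[C@H](CO)[C@@H](O)[C@H](O)[C@H]2O)OC=C(C(=O)OC)[C@H]1CC(=O)OCCC1CCCCC1` – 2000 nM
Compound 2 `C/C=C1/[C@H](O[C@@H]2O[C@H](COC(C)=O)[C@@H](OC(C)=O)[C@H](OC(C)=O)[C@H]2OC(C)=O)OC=C(C(=O)OC)[C@H]1CC(=O)O` – > 15000 nM (a limit of the assay)
Compound 3 `C/C=C1/[C@H](O[C@@H]2O[C@H](COC(C)=O)[C@@H](OC(C)=O)[C@H](OC(C)=O)[C@H]2OC(C)=O)OC=C(C(=O)OC)[C@H]1CC(=O)OCCC1CCCCC1` – > 15000 nM (a limit of the assay)

Within the data shown here, in a functional assay on SK-BR-3 cells (Homo sapiens) for antiproliferative activity, read by MTT assay, with a stated time of 72 h (a lower number here means a stronger inhibitor, a higher number a weaker inhibitor), compound 1 gives 2000 nM, the only number among the three values shown. Compound 2 reaches only the limit of the assay, at > 15000 nM. Compound 3 likewise sits at a limit, > 15000 nM. Among the measured compounds shown here, the one step between measured compounds that differ in a single place, a step that the two limits leave unreadable from compound 2 to compound 3, is therefore of a size that cannot be read, since both ends rest on (the limit of > 15000 nM in this assay, at which 2 of the 3 values shown sit).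

Compound 4 `C/C=C1/[C@H](O[C@@H]2O[C@H](CO)[C@@H](O)[C@H](O)[C@H]2O)OC=C(C(=O)OC)[C@H]1CC(=O)O` is not yet measured. It differs from compound 1 by hydrogen in place of 2-cyclohexylethyl on an oxygen next to a carbonyl group. The step from compound 2 to compound 3 is the same change, taken in the opposite direction, but its two limits leave its size unreadable, so it tells little about what to expect. For the measured compounds named here, compound 1 is the only compound with a number, and both compounds lacking the number carry the acetylated sugar rather than the change at hand. The account therefore expects compound 4 to be weaker than compound 1, with the step of a 7.5-fold higher number from compound 1 to compound 4 (0.88 log units; beyond the scatter) in this assay estimated, and a fair chance that only a limit is reported. For compound 4 the estimate in this assay is 15000 nM, within 4000 nM to 50000 nM.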

Compound 4, half-maximal inhibitory concentration: > 15000 nM
Compound 4 was reported as a limit; the forecaster's own chance of this, stated with the estimate: 60%; the middle value lies on the limit itself.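

In this assay, hydrogen in place of 2-cyclohexylethyl on an oxygen next to a carbonyl group gives an at least 7.5-fold higher number from compound 1 to compound 4 (0.87 log units; beyond the scatter), the first readable measure of this change, and it shows that with the unacetylated sugar the number of compound 1 depends on the 2-cyclohexylethyl group at this position. The earlier pair could not show this: the same change between compound 2 and compound 3, which both carry the acetylated sugar, cannot be read, since both of its ends are limits. Compound 4 itself gives only a limit of the assay, > 15000 nM, so the step fixes a smallest size and no largest one: the limit of > 15000 nM in this assay, at which 3 of the 4 values shown sit.

The compounds shown leave open whether 2-cyclohexylethyl is needed in particular, or whether a shorter ethyl group, an open octyl chain or a 2-phenylethyl group on the same oxygen would keep a readable number in this assay. They also leave open whether an amide in place of this ester, or a chain ending in an amine, would do the same on the core of compound 1.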